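The source may hold more compounds than are shown below. What is called first, only, known or untested is meant among the compounds shown, and "the series" means these compounds.

Measured so far: compound 1 `O=C(Nc1ccc(Oc2ccc(-c3nccs3)cc2)cc1)Nc1cccc(C(F)(F)F)c1` with 71.5%; compound 2 `O=C(Nc1ccccc1)Nc1ccc(Oc2ccc(-c3ncc[nH]3)cc2)cc1` with 7.09%; compound 3 `O=C(Nc1ccc(Oc2ccc(-c3ncc[nH]3)cc2)cc1)Nc1ccc(Cl)c([N+](=O)[O-])c1` with 12.4%.

In a functional assay on A549 cells (Homo sapiens) for inhibition, read by MTT assay and WST assay, with a stated time of 72 h, tested at 10 uM (a higher number here means more inhibition of growth at the concentration tested, a lower number less inhibition of growth), compound 3 stands second highest of the three numbers; its nearest neighbour is compound 2, and the gap between the two lies within the scatter, while compound 1 sits far above it, beyond the scatter. Within the data shown here, the only single-point step among the measured compounds, a number 5.3 percentage points higher from compound 2 to compound 3 (within the scatter), shows that changing phenyl to 4-chloro-3-nitrophenyl on the amide-type nitrogen left this assay essentially unchanged.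

Compound 4 `O=C(Nc1ccc(Oc2ccc(-c3ncc[nH]3)cc2)cc1)Nc1cccc(C(F)(F)F)c1` is still to be measured. It differs from compound 3 by 3-(trifluoromethyl)phenyl in place of 4-chloro-3-nitrophenyl on an amide-type nitrogen. Among the measured compounds shown here, the one step that bears directly on a change of this aryl group, from compound 2 to compound 3, was within the scatter, which argues for little movement. Against that, compound 1 carries the same 3-(trifluoromethyl)phenyl on its urea and gives 71.5%, but its core is not the core shared by compounds 2, 3 and 4, so no step can be drawn from it. The expectation is therefore an uncertain, moderate rise, a number 22.6 percentage points higher from compound 3 to compound 4 (beyond the scatter), and compound 4 is estimated at 35% in this assay, with a range from 8% to 70%.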

Compound 4, percent growth inhibition at one concentration: 30%
Estimate against measurement, compound 4: 5 percentage points above, within the range that was stated.
By their numbers in this assay, from the lowest: compounds 2 and 3 (each within the scatter of the next); then compound 4; then compound 1.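

In this assay 3-(trifluoromethyl)phenyl in place of 4-chloro-3-nitrophenyl on the amide-type nitrogen gives a number 17.6 percentage points higher from compound 3 to compound 4 (beyond the scatter) and trifluoromethyl in place of hydrogen on an aromatic carbon gives a number 22.9 percentage points higher from compound 2 to compound 4 (beyond the scatter) so the aryl group at this position can move the read-out, which the earlier step within the scatter did not show. With 3-(trifluoromethyl)phenyl held constant, 1H-imidazol-2-yl in place of 1,3-thiazol-2-yl gives a number 41.5 percentage points lower from compound 1 to compound 4 (beyond the scatter) and this large step shows that most of the distance to compound 1 lies in that ring exchange and not in the aryl group on the amide-type nitrogen. Nothing measured here accounts for any of these steps.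

Still open, going by these compounds, is whether 1,3-thiazol-2-yl in place of 1H-imidazol-2-yl gives a similar step when the amide-type nitrogen carries phenyl or 4-chloro-3-nitrophenyl. On these data alone, it is also open how an amine or a carboxylic acid in place of the trifluoromethyl group would read in this assay on either core.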